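Acetamido in place of nitro: cytotoxicity notes

The source may report more compounds than this note shows. Statements on the series, on what has been measured and on what is new or still open speak of the compounds shown alone.

Measured so far in an ADME assay on MCF-10A cells (Homo sapiens) for cytotoxicity, read by WST assay, with a stated time of 48 h; on this read-out higher numbers stand for weaker inhibition and lower numbers for stronger inhibition:
- Compound 1 `O=C(NNC(=S)Nc1ccccc1[N+](=O)[O-])c1ccncc1` gives > 300000 nM, which is a limit of the assay.
- Compound 2 `O=C(NNC(=S)Nc1ccc([N+](=O)[O-])cc1)c1ccncc1` gives > 300000 nM, which is a limit of the assay.
- Compound 3 `CCc1cccc(NC(=S)NNC(=O)c2ccncc2)c1` gives > 300000 nM, which is a limit of the assay.

Compound 2 therefore stands on a limit and not on a number. Within the data shown here, all three values sit at the same place, (the limit of > 300000 nM in this assay, at which 3 of the 3 values shown sit), so the set gives no ranking among compounds 1, 2 and 3 and no step between any two of them can be sized. Among the measured compounds shown here, none of the measured pairs differs in a single place.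

Compound 4 `CC(=O)Nc1ccc(NC(=S)NNC(=O)c2ccncc2)cc1` is related to compound 2 by one change: acetamido in place of nitro on an aromatic carbon. For the measured compounds named here, no measured step covers this change, and no value so far lies inside the measurable window, so the only footing is that compound 2 is at the limit.

Expectation: the step from compound 2 to compound 4 in this assay is expected to be none beyond the scatter, a step that the limit leaves unreadable from compound 2 to compound 4, with the most likely outcome that compound 4 is again reported only as a limit. The estimate for compound 4 in this assay is 400000 nM, with a range from 150000 nM to 1500000 nM.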

Compound 4, half-maximal inhibitory concentration: > 300000 nM
Compound 4 was reported as a limit; the forecaster's own chance of this, stated with the estimate: 85%; the middle value lies beyond the limit too.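

No step can be read from compound 2 to compound 4 in this assay, as both compounds are reported only as a limit of the assay: the limit of > 300000 nM in this assay, at which 4 of the 4 values shown sit.

The compounds shown leave open whether acetamido in place of nitro on an aromatic carbon has any effect on cytotoxicity, and how compound 1, compound 2, compound 3 and compound 4 rank.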